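The compounds below may be only part of what the source reports. "The series", "measured", "known", "first", "only" and "open" are said of these compounds alone.

Compound 1 `CCCC(=O)Nc1ccn([C@@H]2CO[C@H](CO)O2)c(=O)n1` bears a propyl group on the carbonyl carbon of its amide. Among the measured compounds shown here, in a functional assay on A549 cells (Homo sapiens) for cytotoxicity, read by sulforhodamine B assay, with a stated time of 72 h (a higher number here means a weaker inhibitor, a lower number a stronger inhibitor), compound 1 gives 6600 nM, the highest of the two numbers measured so far, while compound 2 `CCCCCCCCCC(=O)Nc1ccn([C@@H]2CO[C@H](CO)O2)c(=O)n1` gives 24 nM. For the measured compounds named here, the single measured step, a 280-fold lower number from compound 1 to compound 2 (2.44 log units; beyond the scatter), is hexyl in place of hydrogen on a saturated chain carbon, three bonds along the chain from a carbonyl carbon. Compound 3 `O=C(Nc1ccn([C@@H]2CO[C@H](CO)O2)c(=O)n1)c1ccc(Cl)cc1Cl` is yet to be measured in this assay; it differs from compound 1 by 2,4-dichlorophenyl in place of propyl on a carbonyl carbon. Going by the values given here, no measured step exchanges a chain for an aromatic ring, so the one step bears only loosely on this change: it shows that a larger group on the carbonyl carbon can lower the number greatly, but the group entering here is a ring rather than a longer chain. Compound 3 is therefore expected to show a moderate lowering, a 4.4-fold lower number from compound 1 to compound 3 (0.64 log units; beyond the scatter), with an estimated 1500 nM and a range from 200 nM to 12000 nM.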

Compound 3, half-maximal inhibitory concentration: 9830 nM
For compound 3 the middle estimate is 6.6-fold (0.82 log units) below the measured one; measured number inside the range.
By their numbers in this assay, from the lowest: compound 2; then compounds 1 and 3 (each within the scatter of the next).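

In this assay, 2,4-dichlorophenyl in place of propyl on the carbonyl carbon gives a 1.5-fold higher number from compound 1 to compound 3 (0.17 log units; within the scatter) and so leaves the two numbers indistinguishable. The entering group has more heavy atoms than propyl, so a larger group at this position does not by itself bring the large change seen with the longer chain in a 280-fold lower number from compound 1 to compound 2 (2.44 log units; beyond the scatter) and the kind of group matters as well as its size, at least across these compounds. Nothing available accounts for this difference between the chain and the ring.

As far as these compounds go, it remains open whether a plain phenyl or a benzyl group on the carbonyl carbon would behave like 2,4-dichlorophenyl. The compounds shown also leave open how the number moves along chains of intermediate length, such as pentyl or heptyl.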